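Cytotoxicity notes: selenium to sulfur exchange on compound 1

A few compounds are considered here, and "the series" means these few. Any claim that something is new, unique, unknown or untested is made for them only; others in the source may bear on it.

Compound 1 `O=[N+]([O-])c1cc(Cn2nnc([Se]Cc3ccccc3)n2)cc([N+](=O)[O-])c1`: 118000 nM
Compound 2 `O=[N+]([O-])c1ccc(C[Se]c2nnn(Cc3ccccc3)n2)c([N+](=O)[O-])c1`: 22000 nM

In an ADME assay on CHO-K1 cells (Cricetulus griseus) for cytotoxicity, read by MTT assay, with a stated time of 24 h (on this read-out higher numbers stand for weaker inhibition and lower numbers for stronger inhibition), compound 1 gives 118000 nM, the highest of the two numbers recorded. Its nearest neighbour, compound 2, gives 22000 nM in this assay, a gap that lies beyond the usual scatter. Compound 3 `O=[N+]([O-])c1cc(Cn2nnc(SCc3ccccc3)n2)cc([N+](=O)[O-])c1` has not been measured. It differs from compound 1 by a group of 8 heavy atoms (7 carbon, 1 sulfur; one six-membered aromatic ring of carbon only) in place of a group of 8 heavy atoms (7 carbon, 1 selenium; one six-membered aromatic ring of carbon only), on an aromatic carbon. Among the compounds with values here, no measured pair shows this exchange, so the step is expected to be small, at most a modest move toward weaker inhibition. Compound 3 is expected to give 150000 nM in this assay, within 60000 nM to 400000 nM, an expected step of a 1.3-fold higher number from compound 1 to compound 3 (0.10 log units; within the scatter).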

Compound 3, half-maximal inhibitory concentration: 148000 nM
Compound 3: middle estimate off by 1.0-fold (0.01 log units), on the high side; low and high end bracket the measured number.
By their numbers in this assay, from the lowest: compound 2; then compounds 1 and 3 (each within the scatter of the next).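

Selenium to sulfur exchange on this aromatic carbon, which gives benzylsulfanyl, is the first single-place change in the series. In this assay it gives a 1.3-fold higher number from compound 1 to compound 3 (0.10 log units; within the scatter), so compound 1 and compound 3 cannot be told apart on this read-out, and selenium is not required for the high number seen with compound 1. Nothing measured here bears on a cause for this result.

Open, going by these compounds, is whether the same exchange behaves alike on the core of compound 2. Also open, on these data alone, is how an amine or a longer chain at this position would read.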